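The compounds below may be only part of what the source reports. "The series", "measured", "known", "first", "only" and "open" are said of these compounds alone.

Measured compounds:
Compound 1, `N/C(=N\NC(=S)N1CCCCCC1)c1ccccn1`; in a functional assay on MCF7 cells (Homo sapiens) for cytotoxicity, read by MTT assay, with a stated time of 72 h, tested at 30 uM (a lower number here means less inhibition of growth, a higher number more inhibition of growth at the concentration tested), compound 1 gives 76.5%.
Compound 2, `Cc1ccnc(/C(N)=N/NC(=S)N2CCCCCC2)c1`; compound 2 gives 75.9%.
Compound 3, `Cc1cccc(/C(N)=N/NC(=S)N2CCCC2)n1`; compound 3 gives 40.1%.

Compounds 1 and 2 differ in one place, (hydrogen in place of methyl on an aromatic carbon), and the step of a number 0.6 percentage points higher from compound 2 to compound 1 (within the scatter) lies within the scatter, so the two values cannot be told apart. Compound 3 stands lowest of the three; its values against compound 2 and against compound 1 both differ beyond the scatter. How the core of compound 3 differs from that of compound 2 is not broken down here.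

Compound 4, `N/C(=N\NC(=S)N1CCCC1)c1ccccn1`, is unmeasured and differs from compound 3 in one place, (hydrogen in place of methyl on an aromatic carbon). This is the same kind of change as that from compound 2 to compound 1, not the same: there the methyl sat opposite the ring nitrogen, here it sits next to the ring nitrogen. Because the step of a number 0.6 percentage points higher from compound 2 to compound 1 (within the scatter) stayed within the scatter, a step of similar size is expected here, a number 1.9 percentage points higher from compound 3 to compound 4 (within the scatter). Compound 4 is therefore estimated at 42%, within 25% to 60%.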

Compound 4, percent growth inhibition at one concentration: 54.6%
The estimate for compound 4 lay 12.6 percentage points below the measured number; the measured number falls inside the stated range.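

In this assay, hydrogen in place of methyl on an aromatic carbon gives a number 14.5 percentage points higher from compound 3 to compound 4 (beyond the scatter), whereas the same kind of change on the other core gave a number 0.6 percentage points higher from compound 2 to compound 1 (within the scatter). Set side by side, the two steps cannot be told apart: the same change on two cores in this assay, a number 0.6 percentage points higher (within the scatter) from compound 2 to compound 1 and a number 14.5 percentage points higher (beyond the scatter) from compound 3 to compound 4, 13.9 percentage points apart, within the scatter of two such steps. Among these compounds, this gives no ground for saying that the change behaves differently on the two cores, but it does not show that the change carries over unaltered either: the methyl stands in a different place on the ring in the two pairs, and only two pairs are at hand.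

The compounds shown leave open whether a methyl placed as in compound 3 would give a similar step on the core of compound 1, which would separate the place of the group from the core. They also leave open how groups other than methyl, such as a methoxy group or a chlorine atom, would fare on the same aromatic carbon.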